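Dropping the Hydroxy from an Anilide in a Paw-Edema Series

The source may report more compounds than this note shows. Statements on the series, on what has been measured and on what is new or still open speak of the compounds shown alone.

Compound 1 `CNC(=O)c1nc(-c2cc(OC)c(OC)c(OC)c2)n(-c2ccc(OC)cc2)n1`: 95%
Compound 2 `COc1ccc(-n2nc(C(=O)Nc3ccccc3OC)nc2-c2cc(OC)c(OC)c(OC)c2)cc1`: 38%
Compound 3 `COc1ccc(-n2nc(C(=O)Nc3ccc(O)cc3)nc2-c2cc(OC)c(OC)c(OC)c2)cc1`: 64%

All three were tested in a functional assay on the whole organism for inhibition, with Rattus norvegicus as the target, read by paw edema, with stated times of 30 min and 3 h, at a dose of 0.28 mmol/kg by the oral route; on this read-out higher numbers stand for more inhibition at the one dose given (going by the name of the read-out) and lower numbers for less inhibition. Compound 3 stands second highest of the three numbers, with compound 2 nearest and compound 1 furthest. The step of a number 26 percentage points higher from compound 2 to compound 3 (beyond the scatter) was modest, while a number 57 percentage points lower from compound 1 to compound 2 (beyond the scatter) and a number 31 percentage points lower from compound 1 to compound 3 (beyond the scatter) were both large. Compound 4 `COc1ccc(-n2nc(C(=O)Nc3ccccc3)nc2-c2cc(OC)c(OC)c(OC)c2)cc1` differs from compound 3 only by hydrogen in place of hydroxy on an aromatic carbon. Among the compounds with values here, no measured step removes a hydroxy; the only guide is that the two anilides sit well under the methyl amide and that exchanging one aryl group for another, a number 26 percentage points higher from compound 2 to compound 3 (beyond the scatter), moved the read-out only modestly. Compound 4 is therefore expected to fall slightly, or to stay within the scatter, relative to compound 3, a step estimated at a number 12 percentage points lower from compound 3 to compound 4 (beyond the scatter). Compound 4 is estimated at 52%, between 30% and 75%.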

Compound 4, a percentage reported as inhibition, in the whole organism at one dose (the size of the read-out at that dose, not a potency): 69%
The estimate for compound 4 lay 17 percentage points below the measured number; low and high end bracket the measured number.
By their numbers in this assay, from the lowest: compound 2; then compounds 3 and 4 (each within the scatter of the next); then compound 1.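

In this assay, hydrogen and hydroxy on this aromatic carbon cannot be told apart (a number 5 percentage points higher from compound 3 to compound 4 (within the scatter)), so the hydroxy is not required for the level of inhibition seen with compound 3. The plain phenyl amide still differs from the 2-methoxyphenyl amide (a number 31 percentage points higher from compound 2 to compound 4 (beyond the scatter)) and from the methyl amide (a number 26 percentage points lower from compound 1 to compound 4 (beyond the scatter)), so the gap to compound 1 remains without the hydroxy. No measured evidence accounts for these numbers. Going by these compounds, whether an amine or a carboxylic acid in the same place would give a different number stays open, as does whether ethyl on the amide nitrogen would match methyl.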